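Cytotoxicity notes on a prenylated chalcone ether series

The source may hold more compounds than are shown below. What is called first, only, known or untested is meant among the compounds shown, and "the series" means these compounds.

Measured so far in an ADME assay on L02 cells (Homo sapiens) for cytotoxicity, read by MTT assay; a higher number here means a weaker inhibitor, a lower number a stronger inhibitor:
- compound 1 `COc1ccc(/C=C/C(=O)c2ccc(OC)c3c2OC(C)(C)C=C3)cc1OCC=C(C)C` gives > 10000 nM, a limit of the assay and not a number.
- compound 2 `C#CCOc1cc(/C=C/C(=O)c2ccc(OC)c3c2OC(C)(C)C=C3)ccc1OC` gives > 10000 nM, likewise only a limit.
- compound 3 `COc1ccc(/C=C/C(=O)c2ccc(OC)c3c2OC(C)(C)C=C3)cc1OC(=O)c1ccc(Br)cc1` gives 8400 nM.

Compound 2 stands at the limit, alongside compound 1, as noted in the limit of > 10000 nM in this assay, at which 2 of the 3 values shown sit; only compound 3 returns a number, and that number lies close to the limit. The unmeasured compound 4 `COc1ccc(/C=C/C(=O)Oc2cc(/C=C/C(=O)c3ccc(OC)c4c3OC(C)(C)C=C4)ccc2OC)cc1` differs from compound 2 in one place: (2-(4-methoxyphenyl)ethenyl)carbonyl in place of propargyl on an oxygen on an aromatic ring.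

Within the data shown here, the step that bears on this is the one from compound 2 to compound 3, where an ester replaced the propargyl group on the same oxygen and gave an at least 1.1-fold lower number from compound 2 to compound 3 (0.07 log units; that floor lies within the scatter), a floor that sits within the scatter. The parallel step an at least 1.1-fold lower number from compound 1 to compound 3 (0.07 log units; that floor lies within the scatter) shows the same. The step that the two limits leave unreadable from compound 1 to compound 2 cannot be read. Compound 4 carries an ester on that oxygen as well, so the expectation in this assay is a step of about an at least 1.1-fold lower number from compound 2 to compound 4 (0.04 log units; that floor lies within the scatter), that is, no change beyond the scatter from the limit. For compound 4 the estimated value is 9000 nM, expected to lie between 4500 nM and 20000 nM, with a fair chance that the assay again reports only a limit.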

Compound 4, half-maximal inhibitory concentration: 18000 nM
Estimate against measurement, compound 4: 2.0-fold (0.30 log units) below; low and high end bracket the measured number.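

At this oxygen on an aromatic ring, two esters now return numbers in this assay, so the group on the carbonyl carbon can be compared directly: 2-(4-methoxyphenyl)ethenyl in place of 4-bromophenyl gives a 2.1-fold higher number from compound 3 to compound 4 (0.33 log units; beyond the scatter). The ester link alone therefore does not fix the read-out, and in this pair the group carried on the carbonyl carbon changes the number beyond the scatter, towards weaker inhibition in this L02 cell read-out. The steps from the two ethers, compound 1 and compound 2, to compound 4 cannot be read, because those ethers stand at a limit of the assay and not at a number: the limit of > 10000 nM in this assay, at which 2 of the 4 values shown sit.

With only compound 3 and compound 4 as a readable pair, the bromine, the methoxy group and the ethenyl link all change together, and the step cannot be assigned to any one of them. Going by these compounds, how a plain acetyl group, an amide link or a chain ending in an amine would read at this oxygen remains open.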